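Isopropyl replacement on the aromatic ring of compound 1

The compounds below may be only part of what the source reports. "The series", "measured", "known", "first", "only" and "open" are said of these compounds alone.

Compound 1 `O=C(O)/C=C/C(=O)c1ccccc1` anchors the series. Going by the values given here, in a functional assay on K562 cells (Homo sapiens) for inhibition, read by MTT assay, with a stated time of 72 h (a higher number here means a weaker inhibitor, a lower number a stronger inhibitor), compound 1 gives 30200 nM, the only numerical value obtained so far. Compound 2 `COc1ccc(C(=O)/C=C/C(=O)O)c(OC)c1OC` yields only a limit in this assay, > 100000 nM, which is the limit of > 100000 nM in this assay, at which 1 of the 2 values shown sits. Compound 3 `CC(C)c1ccc(C(=O)/C=C/C(=O)O)cc1` differs from compound 1 by isopropyl in place of hydrogen on an aromatic carbon. Among the compounds with values here, no measured pair shows how this kind of change plays out, so the expected step in this assay is small, in either direction, and likely not beyond the usual scatter. The expected step is a 1.4-fold lower number from compound 1 to compound 3 (0.14 log units; within the scatter). Compound 3 is therefore estimated at 22000 nM, within 8000 nM to 60000 nM.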

Compound 3, half-maximal inhibitory concentration: 5560 nM
Estimate against measurement, compound 3: 4.0-fold (0.60 log units) above; the whole stated range lies above it.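

Isopropyl in place of hydrogen on an aromatic carbon, para to a group of 7 heavy atoms, brings a 5.4-fold lower number from compound 1 to compound 3 (0.73 log units; beyond the scatter) in this assay. Going by these compounds alone, this is the first measured step, and it shows that the number responds to substitution at this position, with isopropyl giving a stronger inhibitor than compound 1. Nothing shown gives a reason for the size of this step.

Open, as far as these compounds go, is whether the step is specific to isopropyl or extends to other groups at this place, such as methyl, tert-butyl or an amine. Also open, from the compounds shown here alone, is how the other aromatic carbons respond to a single isopropyl.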